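The source may report more compounds than this note shows. Statements on the series, on what has been measured and on what is new or still open speak of the compounds shown alone.

Among the measured compounds shown here, compound 1 `ClCc1cccc(Cn2cnc3nc(Cl)nc(Cl)c32)c1` holds the lower of the two numbers known so far in a functional assay on NCI-H522 cells (Homo sapiens) for cytotoxicity, read by sulforhodamine B assay, with a stated time of 48 h; a lower number here means a stronger inhibitor of growth, a higher number a weaker inhibitor of growth: in that test compound 1 gives 1810 nM. Compound 2 `ClCc1ccc(Cn2cnc3ncnc(Cl)c32)cc1` gives 4260 nM in this assay, a gap beyond the usual scatter. Compound 3 `ClCc1cccc(Cn2cnc3ncnc(Cl)c32)c1` has not yet been measured. Relative to compound 1 it carries the change (hydrogen in place of chloro on an aromatic carbon), on an aromatic carbon between two ring nitrogen atoms of the shared core. For the measured compounds named here, no measured pair shows this change by itself, so its size cannot be read from the data, and compound 2, which also lacks this chloro, differs from compound 3 elsewhere as well. Because compound 1 stands at 1810 nM and compound 2 at 4260 nM, a modest weakening in this assay is expected for compound 3, estimated as a 1.8-fold higher number from compound 1 to compound 3 (0.25 log units; within the scatter). Compound 3 is therefore expected near 3200 nM, within 1300 nM to 8000 nM.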

Compound 3, concentration for 50% growth inhibition: 6160 nM
Compound 3: middle estimate off by 1.9-fold (0.28 log units), on the low side; low and high end bracket the measured number.
By their numbers in this assay, from the lowest: compound 1; then compounds 2 and 3 (each within the scatter of the next).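

Replacing the chloro on the aromatic carbon between two ring nitrogen atoms with hydrogen gives, in this assay, a 3.4-fold higher number from compound 1 to compound 3 (0.53 log units; beyond the scatter). Among the compounds shown here, this is the first reading of the change by itself, and it ties the chloro at this position to stronger growth inhibition on the shared core, a link that compound 2, with its further difference, could not establish. No measured evidence at hand accounts for the size of this step.

From the compounds shown here alone, only chloro and hydrogen are compared at this carbon, so the effect of an amine, a methoxy group or a fluoro there remains open. Going by these compounds, whether the step would keep its size with the chloromethyl group placed as in compound 2 also remains open.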